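The compounds below may be only part of what the source reports. "The series", "measured", "known", "first", "only" and "open" are said of these compounds alone.

In a functional assay on HeLa cells (Homo sapiens) for inhibition, read by CCK-8 assay, with a stated time of 48 h (a lower number here means a stronger inhibitor, a higher number a weaker inhibitor), compound 3 `O=C(NCCNS(=O)(=O)c1ccc(-c2ccccc2OCc2ccccc2)s1)Nc1cccc([N+](=O)[O-])c1` gives > 20000 nM as a limit and not a number, which places it at the limit of > 20000 nM in this assay, at which 1 of the 3 values shown sits, and gives no exact starting point.

The next compound, compound 4 `Cc1cc(C)cc(NC(=O)NCCNS(=O)(=O)c2ccc(-c3ccccc3OCc3ccccc3)s2)c1`, carries 3,5-dimethylphenyl in place of 3-nitrophenyl on an amide-type nitrogen and is otherwise the same.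

Compound 2 `O=[N+]([O-])c1ccc(NC(=S)NCCNS(=O)(=O)c2ccc(-c3ccccc3OCc3ccccc3)s2)cc1` gives 7100 nM in this assay. For the measured compounds named here, the only measured step is an at least 2.8-fold higher number from compound 2 to compound 3 (0.44 log units; beyond the scatter), and it does not make this exchange, so it bears on the expectation only indirectly. The closest guide is compound 1 `Cc1cc(C)cc(NC(=O)NCCNS(=O)(=O)c2ccc(-c3ccccc3Oc3ccc([N+](=O)[O-])c([N+](=O)[O-])c3)s2)c1`, which holds the same 3,5-dimethylphenyl group on a different core and gives 12000 nM in this assay.

On that value of compound 1, a modest step towards a lower number is expected in this assay, though one that may stay close to the limit. The estimated change is an at least 1.4-fold lower number from compound 3 to compound 4 (0.15 log units; that floor lies within the scatter). The estimate for compound 4 is 14000 nM with an expected range from 6000 nM to 30000 nM.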

Compound 4, half-maximal inhibitory concentration: > 50000 nM
Compound 4: no number, only a limit; the forecaster's own chance of this, stated with the estimate: 45%; middle value at least 3.5-fold (0.55 log units) from the limit.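

In this assay compound 4 ends at a limit and not a number, as compound 3 does, so the exchange of 3-nitrophenyl for 3,5-dimethylphenyl on the amide-type nitrogen cannot be read as a step: the limit of > 50000 nM in this assay, at which 1 of the 4 values shown sits.

Two other steps can be read: an at least 7.0-fold higher number from compound 2 to compound 4 (0.84 log units; beyond the scatter), and, with benzyl in place of 3,4-dinitrophenyl on an oxygen on an aromatic ring, an at least 4.1-fold higher number from compound 1 to compound 4 (0.61 log units; beyond the scatter). So 3,5-dimethylphenyl on this nitrogen gives an exact number with 3,4-dinitrophenyl on that oxygen but only a limit with benzyl there.

Going by these compounds, how far the two groups on the amide-type nitrogen really stand apart stays open. Also open, on these data alone, is whether an aminophenyl or a carboxylic acid on that phenyl ring would give an exact number with benzyl kept in place.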